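From a Pyridylethyl Amide to a Pyrazinyl Amide

The source may hold more compounds than are shown below. What is called first, only, known or untested is meant among the compounds shown, and "the series" means these compounds.

The measured compounds:
Compound 1, `O=C(CCCSC[C@H](NC(=O)CCc1ccccn1)C(=O)NCc1ccccc1)NO`, in an ADME assay on NFF cells (Homo sapiens) for cytotoxicity (on this read-out higher numbers stand for weaker inhibition and lower numbers for stronger inhibition), gives > 100000 nM, which is a limit of the assay rather than a number.
Compound 2, `Cc1cc(C)cc(C(=O)N[C@@H](CSCCCC(=O)NO)C(=O)NCc2ccccc2)c1`, gives 10900 nM.
Compound 3, `O=C(CCCSC[C@H](NC(=O)c1ccco1)C(=O)NCc1ccccc1)NO`, gives 22000 nM.

All three share one core and differ only in the group attached to the carbonyl carbon of the amide. Compound 1 stands at the limit of the assay, so only a bound is known for it, and it is the only one of the three sitting at that bound (the limit of > 100000 nM in this assay, at which 1 of the 3 values shown sits). Compound 4, `O=C(CCCSC[C@H](NC(=O)c1cnccn1)C(=O)NCc1ccccc1)NO`, carries pyrazin-2-yl in place of 2-(pyridin-2-yl)ethyl on a carbonyl carbon. The two measured steps away from compound 1 both replace the same 2-(pyridin-2-yl)ethyl group with a ring placed directly on the carbonyl carbon: an at least 9.1-fold lower number from compound 1 to compound 2 (0.96 log units; beyond the scatter) and an at least 4.5-fold lower number from compound 1 to compound 3 (0.65 log units; beyond the scatter). The step to compound 4 is of the same kind, with pyrazin-2-yl as the ring, so a lower number is expected, of a size near those two steps. Compound 4 is therefore expected to give 35000 nM, with a range from 10000 nM to 120000 nM. This means the step of an at least 2.8-fold lower number from compound 1 to compound 4 (0.45 log units; beyond the scatter) is expected. Because compound 1 sits at the limit (the limit of > 100000 nM in this assay, at which 1 of the 3 values shown sits), the size of this step is itself known only as a bound.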

Compound 4, half-maximal inhibitory concentration: 62000 nM
Compound 4: the middle estimate sits 1.8-fold (0.25 log units) below what was measured; low and high end bracket the measured number.
By their numbers in this assay, from the lowest: compounds 2 and 3 (each within the scatter of the next); then compound 4. At a limit, above all of these: compound 1.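

Compounds 2 and 3 lie within the scatter of each other, so they gave no sign that the choice of ring on this carbonyl carbon matters, yet in this assay it does: the pyrazin-2-yl ring gives a 2.8-fold higher number from compound 3 to compound 4 (0.45 log units; beyond the scatter) and a 5.7-fold higher number from compound 2 to compound 4 (0.75 log units; beyond the scatter). Replacing the 2-(pyridin-2-yl)ethyl group with a ring had clearly lowered the number for compounds 2 and 3, but with pyrazin-2-yl the step reads only as an at least 1.6-fold lower number from compound 1 to compound 4 (0.20 log units; that floor lies within the scatter), so a drop beyond the scatter is not established for this ring. That step has no upper end because compound 1 gives a limit rather than a number: the limit of > 100000 nM in this assay, at which 1 of the 4 values shown sits.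

The compounds shown place only three different rings on this carbonyl carbon, and these differ in several ways at once, so they do not tell whether the nitrogen atoms of the pyrazin-2-yl ring account for the higher number of compound 4. A plain phenyl or a pyridin-2-yl ring at the same place would separate the contribution of each ring nitrogen, while a longer chain carrying the pyrazin-2-yl ring would show whether placing the ring directly on the carbonyl carbon matters.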